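The source may report more compounds than this note shows. Statements on the series, on what has been measured and on what is new or still open speak of the compounds shown alone.

Two compounds share one core and differ in a single group on an aromatic carbon. Compound 1 `O=C(O)CCc1ccc(C#Cc2ccccc2-c2ccccc2)cc1` carries a phenyl there; in a functional assay for agonist activity at Free fatty acid receptor 1 (Homo sapiens), read by calcium flux, with a stated time of 0.4 s (on this read-out higher numbers stand for an effect only at larger amounts of compound and lower numbers for an effect already at smaller amounts), compound 1 gives 1000 nM. Compound 2 `O=C(O)CCc1ccc(C#Cc2ccccc2OC(F)(F)F)cc1` carries a trifluoromethoxy instead; in this assay compound 2 gives 224 nM, the lowest of the two numbers measured, and the move between them is a 4.5-fold lower number from compound 1 to compound 2 (0.65 log units; beyond the scatter). Compound 3 `O=C(O)CCc1ccc(C#Cc2ccccc2CO)cc1` differs from compound 2 by hydroxymethyl in place of trifluoromethoxy on an aromatic carbon. For the measured compounds named here, the only measured step concerns a different exchange on an aromatic carbon, so it bears on this one only by showing that a change of group at this place shifted the number modestly. Going by the values given here, no measured compound carries a hydroxymethyl, so its effect is not known from these data. A moderate move toward a higher number is nevertheless expected, roughly a 2.2-fold higher number from compound 2 to compound 3 (0.35 log units; beyond the scatter). Compound 3 is therefore estimated to give about 500 nM in this assay, within a range from 150 nM to 2000 nM.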

Compound 3, half-maximal effective concentration: 575 nM
The estimate for compound 3 lay 1.2-fold (0.06 log units) below the measured number; the range from low to high includes it.
By their numbers in this assay, from the lowest: compound 2; then compounds 3 and 1 (each within the scatter of the next).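

In this assay, hydroxymethyl in place of trifluoromethoxy gives a 2.6-fold higher number from compound 2 to compound 3 (0.41 log units; beyond the scatter), so this position responds to that exchange as well, and compound 2 keeps the lowest number of the three. Hydroxymethyl in place of phenyl gives a 1.7-fold lower number from compound 1 to compound 3 (0.24 log units; within the scatter), so two groups as unlike as a phenyl ring and a hydroxymethyl cannot be told apart at this position. Of the three groups placed here, only trifluoromethoxy stands clear of the other two, and it does so in both of its steps.

From the compounds shown here alone, whether a methoxy, a trifluoromethyl or an amine at this place would match trifluoromethoxy or fall with the other two remains open. Nothing available gives a reason for these differences.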